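The compounds below may be only part of what the source reports. "The series", "measured", "known", "first", "only" and "open" are said of these compounds alone.

Measured in an assay on HEK293 cells for displacement of a labelled ligand from 5-hydroxytryptamine receptor 4 (Homo sapiens); a lower number here means a stronger inhibitor, a higher number a weaker inhibitor:
compound 1 `CS(=O)(=O)Nc1ccc(CN2CCC(CNC(=O)c3cccc4c3OCCO4)CC2)cc1`: 0.2 nM
compound 2 `CCCCS(=O)(=O)Nc1ccc(CN2CCC(CNC(=O)c3cccc4c3OCCO4)CC2)cc1`: 0.251 nM

Compound 2 has only one neighbour among these two, and the single measured step, a 1.3-fold higher number from compound 1 to compound 2 (0.10 log units; within the scatter), moves the number no more than repeated measurements would, so the two share one level. Compound 3 `CC(C)CS(=O)(=O)Nc1ccc(CN2CCC(CNC(=O)c3cccc4c3OCCO4)CC2)cc1` differs from compound 2 by isopropyl in place of propyl on a saturated chain carbon bound to a sulfonyl sulfur. Within the data shown here, the one step that bears on this place, a 1.3-fold higher number from compound 1 to compound 2 (0.10 log units; within the scatter), showed that adding the whole chain there left the number essentially unchanged, so the expectation is that rearranging it, a 1.2-fold higher number from compound 2 to compound 3 (0.08 log units; within the scatter), also stays within the scatter. Compound 3 is therefore estimated at 0.3 nM, with a range from 0.12 nM to 0.8 nM.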

Compound 3, inhibition constant in the 5-hydroxytryptamine receptor 4 assay: 0.2 nM
The estimate for compound 3 lay 1.5-fold (0.18 log units) above the measured number; the range from low to high includes it.
By their numbers in the 5-hydroxytryptamine receptor 4 assay, from the lowest: compounds 1, 3 and 2 (each within the scatter of the next).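

In the 5-hydroxytryptamine receptor 4 assay, isopropyl in place of propyl on a saturated chain carbon bound to a sulfonyl sulfur stays within the scatter (a 1.3-fold lower number from compound 2 to compound 3 (0.10 log units; within the scatter)), and so does isopropyl in place of hydrogen (no change at the digits printed from compound 1 to compound 3 (within the scatter)), so a branched chain shares the level of the straight chain, with compound 3 at 0.2 nM and compound 2 at 0.251 nM. In a physicochemical assay for lipophilicity, at pH 7.4 (on this read-out higher numbers stand for higher lipophilicity and lower numbers for lower lipophilicity), the same swap also stays within the scatter (no change at the digits printed from compound 2 to compound 3 (within the scatter)), with compound 2 at 1.8 and compound 3 at 1.8. Nothing available explains why this level holds. As far as these compounds go, whether a phenyl ring or an amine at this place would keep the number at that level remains open.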